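The compounds below may be only part of what the source reports. "The series", "measured", "known", "first", "only" and "open" are said of these compounds alone.

- compound 1 `CS(=O)(=O)c1cccc([C@H](CO)NC(=O)c2cc(S(F)(F)(F)(F)F)ccc2Oc2ccccc2)c1` gives 121000 nM
- compound 2 `C[C@H](NC(=O)[C@H]1CCCC[C@@H]1c1ccccc1)c1ccccc1` gives 57000 nM

In a physicochemical assay for solubility, measured as kinetic solubility (a higher number here means a more soluble compound, a lower number a less soluble compound), compound 2 gives 57000 nM, the lower of the two numbers, and the gap up to compound 1 lies beyond the scatter. Compound 3 `O=C(N[C@@H](CO)c1ccccc1)[C@H]1CCCC[C@@H]1c1ccccc1` differs from compound 2 in one place, (hydroxy in place of hydrogen on a saturated chain carbon, two bonds along the chain from an amide-type nitrogen and an aromatic carbon), which reads as methyl to hydroxymethyl when cut one bond further out. Among the compounds with values here, no measured step shows this change, so only an expectation can be offered: a modest rise in this assay, beyond the scatter but not by much. The estimated move is a 1.7-fold higher number from compound 2 to compound 3 (0.22 log units; within the scatter). The expected value for compound 3 is 95000 nM, within an estimated range of 50000 nM to 180000 nM.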

Compound 3, solubility: 455000 nM
Beside the measured number, compound 3's estimate is 4.8-fold (0.68 log units) below it; the measured number lies above the stated range.
By their numbers in this assay, from the lowest: compound 2; then compound 1; then compound 3.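

In this assay, replacing hydrogen with hydroxy on this saturated chain carbon, which reads as methyl to hydroxymethyl, gives an 8.0-fold higher number from compound 2 to compound 3 (0.90 log units; beyond the scatter), so this position responds strongly to this single change. This rests on one matched pair, on the shared core of compound 2 and compound 3. Nothing available here accounts for the size of the step.

As far as these compounds go, whether an amine, a carboxylic acid or a longer chain at this carbon would give a similar step remains open. So does whether the same change would have a similar effect on a different core.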